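A Hydroxy Group on a Compound at the Limit

The source may hold more compounds than are shown below. What is called first, only, known or untested is meant among the compounds shown, and "the series" means these compounds.

Compound 1 `COc1ccc(C2=C(c3cc(OC)c(OC)c(OC)c3)C(=O)CC2O[SiH2]C(C)(C)C)cc1` sits at the edge of the scale: in an ADME assay on KB cells (Homo sapiens) for cytotoxicity, read by MTT assay, with a stated time of 72 h (on this read-out higher numbers stand for weaker inhibition and lower numbers for stronger inhibition), compound 1 gives > 100 ug/mL as a limit and not a number. Compound 2 `COc1cc(C2=C(c3cc(C)c(OC)c(C)c3)C(O)CC2=O)cc(OC)c1OC` reads > 100 ug/mL and this too is a limit. Compound 3 `COc1cc(C2=C(c3cc(C)c(OC)c(C)c3)C(OC(C)=O)CC2=O)cc(OC)c1OC` reads > 100 ug/mL and this is again a limit. Within the data shown here, the one measured step is a step that the two limits leave unreadable from compound 2 to compound 3 and it offers no size to carry over. The whole set shows the limit of > 100 ug/mL in this assay, at which 3 of the 3 values shown sit, and so no true number anchors the series.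

Compound 4 `COc1ccc(C2=C(c3cc(OC)c(OC)c(OC)c3)C(=O)CC2O[SiH2]C(C)(C)C)cc1O` differs from compound 1 by hydroxy in place of hydrogen on an aromatic carbon in the change from 4-methoxyphenyl to 3-hydroxy-4-methoxyphenyl. Among the measured compounds shown here, no measured step concerns hydroxy in place of hydrogen on an aromatic carbon. In this assay a move toward stronger inhibition is therefore expected only tentatively, and a reading that stays at the limit is about as likely. The expected change is an at least 2.0-fold lower number from compound 1 to compound 4 (0.30 log units; that floor lies within the scatter) and its size remains uncertain. Compound 4 is estimated at 50 ug/mL with an expected range from 2 ug/mL to 150 ug/mL in this measurement.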

Compound 4, half-maximal inhibitory concentration: 6.5 ug/mL
For compound 4 the middle estimate is 7.7-fold (0.89 log units) above the measured one; the range from low to high includes it.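

In this assay, hydroxy in place of hydrogen on an aromatic carbon, ortho to a methoxy group, gives an at least 15-fold lower number from compound 1 to compound 4 (1.18 log units; beyond the scatter), so a change at this one position separates a compound at the limit from one with a readable value. Among these compounds, the earlier compounds could show no such thing, as their only step cannot be read and gave no size at all. Compound 4 is the one compound shown that comes off the limit, which still marks the rest of the series: the limit of > 100 ug/mL in this assay, at which 3 of the 4 values shown sit.

The compounds shown leave open whether this step belongs to the hydroxy group itself, or whether an amine, a fluorine or an acetoxy group at the same place would give a readable value too. They also leave open whether the same hydroxy change would carry over to the core of compound 2.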